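Swapping the pyrrolidine for a phenylpiperidine on the core

The source may hold more compounds than are shown below. What is called first, only, known or untested is meant among the compounds shown, and "the series" means these compounds.

Of the compounds shown here, three sharing one core have been measured in a functional assay on CHO-K1 cells for antagonist activity at transient receptor potential cation channel subfamily V member 1 (Homo sapiens), read by FLIPR; on this read-out higher numbers stand for weaker inhibition and lower numbers for stronger inhibition. Compound 1 `Cc1ccc(Cl)cc1Nc1nc(C(F)(F)F)ccc1CNC(=O)C(C)c1ccc(NS(C)(=O)=O)c(F)c1` gives 14 nM, compound 2 `CC1CCCN1c1nc(C(F)(F)F)ccc1CNC(=O)[C@@H](C)c1ccc(NS(C)(=O)=O)c(F)c1` gives 0.3 nM, and compound 3 `C[C@H](C(=O)NCc1ccc(C(F)(F)F)nc1N1CC[C@H](N(C)C)C1)c1ccc(NS(C)(=O)=O)c(F)c1` gives 103 nM. On these numbers compound 3 stands highest of the three: compound 1 sits closest to it with a lower number, and compound 2 lies furthest away with a much lower number. Among the compounds with values here, the one step that can be computed between neighbours is a 340-fold higher number from compound 2 to compound 3 (2.54 log units; beyond the scatter).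

Compound 4 `C[C@H](C(=O)NCc1ccc(C(F)(F)F)nc1N1CCC(c2ccccc2)CC1)c1ccc(NS(C)(=O)=O)c(F)c1` is the next member and has not been measured. It differs from compound 3 in one place: 4-phenylpiperidin-1-yl in place of 3-(dimethylamino)pyrrolidin-1-yl on an aromatic carbon. The only measured step that bears on this position is the large rise from compound 2 to compound 3 described above, which shows that a change of the group on this aromatic carbon can move the read-out a great deal. Within the data shown here, no measured pair contains the 4-phenylpiperidin-1-yl group itself, so the direction can only be argued from the fact that compound 2 and compound 1, which carry other groups at this carbon, both sit well below compound 3. Compound 4 is therefore expected to come in lower than compound 3, with an estimated step of a 17-fold lower number from compound 3 to compound 4 (1.23 log units; beyond the scatter). The estimated value for compound 4 in this assay is 6 nM, expected to lie between 1 nM and 40 nM.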

Compound 4, inhibition constant: 0.3 nM
Compound 4: the middle estimate sits 20-fold (1.30 log units) above what was measured; measured number outside the range, below it.
By their numbers in this assay, from the lowest: compounds 2 and 4 (each within the scatter of the next); then compound 1; then compound 3.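

The change to 4-phenylpiperidin-1-yl on this aromatic carbon, next to the ring nitrogen, gives a 340-fold lower number from compound 3 to compound 4 (2.54 log units; beyond the scatter) in this assay, so the large loss seen with 3-(dimethylamino)pyrrolidin-1-yl is not a general result of placing a larger saturated ring group here. The entering group also adds a six-membered aromatic ring of carbon only, yet the comparison with the small 2-methylpyrrolidin-1-yl group shows no change at the digits printed from compound 2 to compound 4 (within the scatter) and the two groups cannot be told apart on this read-out. The data shown offer no evidence on why 3-(dimethylamino)pyrrolidin-1-yl stands so far from these two groups.

On these data alone, it remains open whether the high number goes with the dimethylamino group or with its placement on the pyrrolidine ring, a question that an unsubstituted pyrrolidin-1-yl group or a 4-(dimethylamino)piperidin-1-yl group at this carbon would address. As far as these compounds go, it is also open how a carboxylic acid or a hydroxyl group on the phenyl ring of the 4-phenylpiperidin-1-yl group would read in this assay.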